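Sulfamoyl in place of cyano, starting from a limit

A few compounds are considered here, and "the series" means these few. Any claim that something is new, unique, unknown or untested is made for them only; others in the source may bear on it.

Measured in an ADME assay on MT4 cells (Homo sapiens) for cytotoxicity, read by MTT assay, with a stated time of 5 days; a lower number here means that less compound is tolerated, a higher number that more compound is tolerated:
- Compound 1 `COc1cc2nc([S+]([O-])CC(=O)Nc3cccc(F)c3)nc(Nc3c(Cl)cc(/C=C/C#N)cc3Cl)c2cc1OC`: 9550 nM
- Compound 2 `COc1cc2nc([S+]([O-])CC(=O)Nc3cccc(C#N)c3)nc(Nc3c(Cl)cc(/C=C/C#N)cc3Cl)c2cc1OC`: >= 70300 nM (a limit)

Compound 2 has no exact number in this assay, only the limit shown. Compound 3 `COc1cc2nc([S+]([O-])CC(=O)Nc3cccc(S(N)(=O)=O)c3)nc(Nc3c(Cl)cc(/C=C/C#N)cc3Cl)c2cc1OC` carries sulfamoyl in place of cyano on an aromatic carbon. Within the data shown here, the only measured step, with cyano in place of fluoro on an aromatic carbon, is an at least 7.3-fold higher number from compound 1 to compound 2 (0.86 log units; beyond the scatter). That step ends at a limit and does not involve sulfamoyl, so it gives no firm direction. No step beyond the scatter is expected, though a lower number remains possible. The estimated step is an at least 1.7-fold lower number from compound 2 to compound 3 (0.24 log units; that floor lies within the scatter). For compound 3 the expected value is 40000 nM, with an estimated range from 10000 nM to 100000 nM.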

Compound 3, half-maximal cytotoxic concentration: 67800 nM
Compound 3: the middle estimate sits 1.7-fold (0.23 log units) below what was measured; low and high end bracket the measured number.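

In this assay, fluoro at this position now has a second replacement with an exact number, sulfamoyl (a 7.1-fold higher number from compound 1 to compound 3 (0.85 log units; beyond the scatter)), so the higher number no longer rests on a limit alone. Sulfamoyl and cyano are not separated here, and the floor of their step lies within the scatter (an at least 1.0-fold lower number from compound 2 to compound 3 (0.01 log units; that floor lies within the scatter)). Compound 2 still has only a limit: the limit of >= 70300 nM in this assay, at which 1 of the 3 values shown sits.

Still open, going by these compounds, is how far above that limit compound 2 might lie. So is how an amine or a carboxylic acid on this aromatic carbon would read in this assay.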